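A few compounds are considered here, and "the series" means these few. Any claim that something is new, unique, unknown or untested is made for them only; others in the source may bear on it.

Two stilbenes share the core of compound 1 `COc1cccc(/C=C/c2cccc(F)c2)c1OC`; compound 2 `COc1cccc(/C=C/c2ccccc2)c1OC` differs only in carrying hydrogen where compound 1 carries fluoro on an aromatic carbon. In an assay on HepG2 cells for activation of nuclear factor erythroid 2-related factor 2 (Homo sapiens), read by a luciferase reporter, with a stated time of 5 h (on this read-out higher numbers stand for an effect only at larger amounts of compound and lower numbers for an effect already at smaller amounts), compound 1 gives 1900 nM and compound 2 gives 4700 nM. Among the measured compounds shown here, compound 2 thus stands at the higher of the two numbers measured so far; the single measured step, a 2.5-fold higher number from compound 1 to compound 2 (0.39 log units; beyond the scatter), is a modest shift and sets compound 2 apart from compound 1 beyond the scatter. The next compound, compound 3 `COc1cccc(/C=C/c2ccc(C(F)(F)F)cc2)c1OC`, is not yet measured in this assay; it differs from compound 2 by trifluoromethyl in place of hydrogen on an aromatic carbon, placed para to a large group. For the measured compounds named here, the only step that bears on this change is a 2.5-fold higher number from compound 1 to compound 2 (0.39 log units; beyond the scatter): taking fluoro away raised the number modestly, so putting a fluorine-containing group back onto an aromatic carbon, now as trifluoromethyl, is expected to lower it by a comparable modest amount, although neither the group nor its place matches compound 1 exactly, which keeps the range wide. For compound 3 the expected shift is a 2.4-fold lower number from compound 2 to compound 3 (0.37 log units; beyond the scatter). Compound 3 is therefore estimated at 2000 nM in this assay, within 700 nM to 6000 nM.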

Compound 3, half-maximal effective concentration: 2200 nM
Compound 3: the middle estimate sits 1.1-fold (0.04 log units) below what was measured, within the range that was stated.
By their numbers in this assay, from the lowest: compounds 1 and 3 (each within the scatter of the next); then compound 2.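

In this assay, placing trifluoromethyl on an aromatic carbon, para to a large group, gives a 2.1-fold lower number from compound 2 to compound 3 (0.33 log units; beyond the scatter), so this position accepts a group of 4 heavy atoms in place of hydrogen, and the number falls rather than rises. Read beside a 2.5-fold higher number from compound 1 to compound 2 (0.39 log units; beyond the scatter), this means that compound 2, with neither substituent, has the higher number in both single-place comparisons, and among these three compounds nothing goes against that pattern. The data offer no measurement that would explain either step.

As far as these compounds go, it remains open whether the lower number depends on fluorine or whether other groups at this position, such as methyl, an amine or a carboxylic acid, would shift it in the same way. Also unresolved is how much the position itself contributes, a question that fluoro at this position and trifluoromethyl at the place occupied by fluoro in compound 1 would address, and whether the step persists when the two methoxy groups of the shared core are changed.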